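This account rests on a few compounds, and the source may have more. Where it says the series, first, only, none or still open, it means among the compounds named here.

Working notes on the series in a functional assay (aorta) with Rattus norvegicus as the target; on this read-out higher numbers stand for an effect only at larger amounts of compound and lower numbers for an effect already at smaller amounts. Compound 1 `COc1ccc(-c2nc(/N=C(\N)NC3CCCCC3)sc2-c2ccc(OC)cc2)cc1` gives > 100 uM, which is a limit. Compound 2 `CNC(=O)NCc1nc(-c2ccc(OC)cc2)c(-c2ccc(OC)cc2)s1` gives 15 uM. Compound 3 `COc1ccc(-c2nc(C(=O)N3CCOCC3)sc2-c2ccc(OC)cc2)cc1` gives < 100 uM, also only a limit, so its standing is open. Compound 4 `CCOC(=O)/C(C#N)=C/c1nc(-c2ccc(OC)cc2)c(-c2ccc(OC)cc2)s1` carries 2-cyano-2-(ethoxycarbonyl)ethenyl in place of (morpholin-4-yl)carbonyl on an aromatic carbon. Among group exchanges on that carbon, only an at least 6.6-fold lower number from compound 1 to compound 2 (0.82 log units; beyond the scatter) has a readable lower bound, and it lies beyond the scatter. The steps of a number no higher from compound 1 to compound 3 (the limit leaves the size open) and a step that the limit leaves unreadable from compound 2 to compound 3 leave their size open. A modest step toward the value of compound 2 at 15 uM is therefore expected, with low confidence: a step that the limit leaves unreadable from compound 3 to compound 4. For compound 4 the estimated value is 30 uM, with an expected range of 7 uM to 100 uM.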

Compound 4, concentration for half-maximal effect: > 100 uM
Compound 4: a limit, no number; the forecaster's own chance of this, stated with the estimate: 30%; middle value at least 3.3-fold (0.52 log units) from the limit.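

In this assay this aromatic carbon now has a second readable step, an at least 6.6-fold higher number from compound 2 to compound 4 (0.82 log units; beyond the scatter), so ((methylcarbamoyl)amino)methyl is set apart from 2-cyano-2-(ethoxycarbonyl)ethenyl as well as from the group of compound 1. The other readable step at this position is an at least 6.6-fold lower number from compound 1 to compound 2 (0.82 log units; beyond the scatter), and both readable steps run through the only compound shown with a number rather than a limit. The data also give a number no lower from compound 3 to compound 4 (the limit leaves the size open); neither that step nor the one from compound 1 to compound 4 can be read: the limit of > 100 uM in this assay, at which 2 of the 4 values shown sit.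

From the compounds shown here alone, it remains open which part of ((methylcarbamoyl)amino)methyl carries the gap. Going by these compounds, how a plain aminomethyl group or a carboxylic acid on this carbon would read in this assay is also open.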